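Ortho substituent swap on the aryl group of the series

The compounds below may be only part of what the source reports. "The series", "measured", "known", "first", "only" and "open" are said of these compounds alone.

Among the measured compounds shown here, compound 2 `CSc1nc(-c2ccccc2O)c(C#N)c(=O)n1C` gives 58 ug/mL in a functional assay, with a stated time of 150 min (a higher number here means a weaker inhibitor, a lower number a stronger inhibitor), and stands second highest of the three numbers so far; compound 3 `CSc1nc(-c2cccc(O)c2O)c(C#N)c(=O)n1C` at 53 ug/mL is nearest and compound 1 `CSc1nc(-c2cccs2)c(C#N)c(=O)n1C` at 87 ug/mL furthest, both within the scatter. Compound 4 `CSc1nc(-c2ccccc2Cl)c(C#N)c(=O)n1C` is not yet measured. It differs from compound 2 by chloro in place of hydroxy on an aromatic carbon, on an aromatic carbon of a six-membered aromatic ring of carbon only, ortho to a large group. For the measured compounds named here, the only measured step in this region, a 1.1-fold lower number from compound 2 to compound 3 (0.04 log units; within the scatter), adds a further hydroxy and stays within the scatter. Going by the values given here, no measured step exchanges hydroxy for chloro, so no direction can be read from the series. The expected step of a 1.0-fold higher number from compound 2 to compound 4 (0.01 log units; within the scatter) is therefore none beyond the scatter. Compound 4 is estimated at 60 ug/mL, with a range from 30 ug/mL to 120 ug/mL.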

Compound 4, half-maximal inhibitory concentration: 81 ug/mL
Estimate against measurement, compound 4: 1.4-fold (0.13 log units) below; measured number inside the range.
By their numbers in this assay, from the lowest: compounds 3, 2, 4 and 1 (each within the scatter of the next).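

In this assay the exchange of hydroxy for chloro on the aromatic carbon ortho to a large group gives a 1.4-fold higher number from compound 2 to compound 4 (0.15 log units; within the scatter) and so moves the number no further than the scatter. The hydrogen-bond donor and acceptor counted on hydroxy leave with it without a readable change, which the added hydroxy of compound 3 could not show. Nothing measured bears on why this exchange gives so small a step. Still open, on these data alone, is whether an amine, a carboxylic acid or a longer chain such as propoxy at this place would carry the number beyond the scatter.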